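Bromomethyl to 1-chloroethyl exchange on two related cores

The compounds below may be only part of what the source reports. "The series", "measured", "known", "first", "only" and "open" are said of these compounds alone.

Measured compounds:
compound 1, `Cc1c(NC(=O)CBr)cccc1C(=O)NC(N)=O`, giving 1710 nM
compound 2, `Cc1ccc(C(=O)NC(N)=O)cc1NC(=O)CBr`, giving 4280 nM
compound 3, `Cc1c(NC(=O)C(C)Cl)cccc1C(=O)NC(N)=O`, a limit of the assay rather than a number, > 20000 nM

All three were run in a functional assay on CCRF-CEM cells (Homo sapiens) for antiproliferative activity, read by trypan blue exclusion, with a stated time of 72 h; a lower number here means a stronger inhibitor, a higher number a weaker inhibitor. Compound 1 and compound 2 carry the same atoms joined differently; how the two cores differ is not broken down here. In this assay compound 2 stands highest of the two numbers, with compound 1 the nearer value.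

Compound 3 is obtained from compound 1 by 1-chloroethyl in place of bromomethyl on a carbonyl carbon. That change gives an at least 11-fold higher number from compound 1 to compound 3 (1.06 log units; beyond the scatter), and the step can be given only as a lower bound because of the limit of > 20000 nM in this assay, at which 1 of the 3 values shown sits.

Not yet measured is compound 4, `Cc1ccc(C(=O)NC(N)=O)cc1NC(=O)C(C)Cl`. It is obtained from compound 2 by 1-chloroethyl in place of bromomethyl on a carbonyl carbon. For the measured compounds named here, the place of the change reads the same in both pairs, so this is the same change as the one from compound 1 to compound 3, here applied to the second core. Both cores are otherwise left untouched.

The step is expected to be a 12-fold higher number from compound 2 to compound 4 (1.07 log units; beyond the scatter). This rests on the measured step of an at least 11-fold higher number from compound 1 to compound 3 (1.06 log units; beyond the scatter) and on compound 2 starting from 4280 nM. Compound 4 is therefore estimated at 50000 nM, with a range from 15000 nM to 200000 nM, and it is expected that this assay will most likely report only a limit for compound 4.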

Compound 4, half-maximal inhibitory concentration: > 20000 nM
Compound 4 ended at the assay's limit (the forecaster's own chance of this, stated with the estimate: 80%); the middle value is on the limit's open side.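

In this assay, 1-chloroethyl in place of bromomethyl on a carbonyl carbon again moves the number the same way on the second core, giving an at least 4.6-fold higher number from compound 2 to compound 4 (0.66 log units; beyond the scatter), so across these two pairs the direction of the change carries from one core to the other: the same change on two cores in this assay, an at least 11-fold higher number (1.06 log units; beyond the scatter) from compound 1 to compound 3 and an at least 4.6-fold higher number (0.66 log units; beyond the scatter) from compound 2 to compound 4; the limit leaves it open whether they differ

Compound 4 gives > 20000 nM, which is a limit of the assay and not a number.

The size of the step is therefore not established on either core, and the data show only a lower bound for each, not whether the two cores respond equally: the limit of > 20000 nM in this assay, at which 2 of the 4 values shown sit.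

The exchange alters the halogen and the carbon count of the group together, and the compounds shown leave open which of these two differences goes with the higher numbers; chloromethyl or 1-bromoethyl on the same carbonyl carbon would separate them. Also open, from the compounds shown here alone, is how either core would read with a group lacking a halogen at this place, such as an amine or a longer chain, and whether the pattern extends beyond these two cores.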